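The source may report more compounds than this note shows. Statements on the series, on what has been measured and on what is new or still open speak of the compounds shown alone.

In an ADME assay on BHK-21 cells (Mesocricetus auratus) for cytotoxicity, read by MTT assay (a higher number here means that more compound is tolerated, a lower number that less compound is tolerated), compound 1, `COc1ccc(-c2nc3cc(C(C)O)ccc3[nH]2)cc1`, gives > 100000 nM, which is a limit of the assay rather than a number. Compound 2, `C/C(=N\NC(N)=O)c1ccc2[nH]c(-c3ccc(C(F)(F)F)cc3)nc2c1`, gives > 100000 nM in this assay, again a limit. For compound 3, `COc1ccc(-c2nc3cc(/C(C)=N/NC(N)=O)ccc3[nH]2)cc1`, the result in this assay is "not determined" (no result reported), so compound 3 stands on no number of its own, and what is known comes from its two neighbours, which both sit at the limit of > 100000 nM in this assay, at which 2 of the 3 values shown sit. Compound 4, `C/C(=N\NC(N)=O)c1ccc2[nH]c(-c3ccoc3)nc2c1`, differs from compound 3 in one place: furan-3-yl in place of 4-methoxyphenyl on an aromatic carbon. Within the data shown here, with no measured step to set the size of this change, the expectation is that compound 4 stays within the usual scatter of its neighbours and shows no shift in this assay. Compound 4 is therefore estimated at 100000 nM, within 50000 nM to 200000 nM, most likely reported once more only as a limit.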

Compound 4, half-maximal cytotoxic concentration: > 100000 nM
Compound 4: no number, only a limit; the forecaster's own chance of this, stated with the estimate: 80%; the middle value lies on the limit itself.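

No step can be read between compound 3 and compound 4, as compound 4 gives only a limit and compound 3 has no number. The compounds shown leave open where toxicity to these cells actually begins: the limit of > 100000 nM in this assay, at which 3 of the 4 values shown sit.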